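Bromo to Iodo on a Growth-Inhibiting Series

The compounds below may be only part of what the source reports. "The series", "measured", "known", "first", "only" and "open" are said of these compounds alone.

For the measured compounds named here, in a functional assay on NFS-60 cells (Mus musculus) for inhibition, with a stated time of 72 h (on this read-out lower numbers stand for stronger inhibition of growth and higher numbers for weaker inhibition of growth), compound 1 (`Nc1ncnc2c(C(=O)Nc3cccc4c3c(Br)nn4Cc3ccncc3)csc12`) gives 135 nM and compound 2 (`Cc1cccc(Cn2nc(Br)c3c(NC(=O)c4csc5c(N)ncnc45)cccc32)n1`) gives 27.5 nM as the lower of the two numbers so far. Going by the values given here, the only measured step is a 4.9-fold lower number from compound 1 to compound 2 (0.69 log units; beyond the scatter) and it came with 6-methylpyridin-2-yl in place of pyridin-4-yl on a saturated chain carbon bound to an aromatic nitrogen.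

The next compound, compound 3 (`Cc1cccc(Cn2nc(I)c3c(NC(=O)c4csc5c(N)ncnc45)cccc32)n1`), keeps everything in compound 2 except for iodo in place of bromo on an aromatic carbon. The measured step lies at a different place, and both measured compounds carry bromo, so no measurement tests this exchange directly. Its size offers no guide here, and no step beyond the scatter is expected in this assay in either direction. The estimate therefore rests on compound 2 at 27.5 nM alone. The expected change is a 1.1-fold lower number from compound 2 to compound 3 (0.04 log units; within the scatter) and it carries no firm direction. Compound 3 is estimated at 25 nM (expected range 10 nM to 70 nM).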

Compound 3, concentration for 50% growth inhibition: 30 nM
The estimate for compound 3 lay 1.2-fold (0.08 log units) below the measured number; measured number inside the range.
By their numbers in this assay, from the lowest: compounds 2 and 3 (each within the scatter of the next); then compound 1.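

Placing iodo in place of bromo on this aromatic carbon of the five-membered aromatic ring gives a 1.1-fold higher number from compound 2 to compound 3 (0.04 log units; within the scatter) in this assay, the first direct reading at this position. Within the shared core and with the (6-methylpyridin-2-yl)methyl group held constant, the two halogens therefore cannot be told apart on this read-out, whereas the only earlier step, a 4.9-fold lower number from compound 1 to compound 2 (0.69 log units; beyond the scatter), came from the other end of the molecule and said nothing about this carbon. No measurement given here accounts for why compound 2 and compound 3 read alike.

With only bromo and iodo shown at this carbon, it remains open whether the same level of growth inhibition would survive a much smaller or quite different substituent there, such as hydrogen, chloro, methyl, an amine or a nitrile. On these data alone, it is also open whether the match between bromo and iodo holds when the pyridin-4-yl group of compound 1 stands on the chain carbon, or when a longer chain links the ring nitrogen to the pyridine.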